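Hydroxymethyl on the pyrrolidine of a quinazoline Chk2 inhibitor

A few compounds are considered here, and "the series" means these few. Any claim that something is new, unique, unknown or untested is made for them only; others in the source may bear on it.

The measured compounds:
compound 1 `Cc1ccc(O)c(-c2nc(N[C@H]3CCNC3)c3ccccc3n2)c1`, 92 nM
compound 2 `COC(=O)[C@@H]1C[C@H](Nc2nc(-c3ccccc3O)nc3ccccc23)CN1`, 4600 nM
compound 3 `Oc1ccc(F)cc1-c1nc(N[C@H]2CCNC2)c2ccccc2n1`, 60 nM

In an assay on isolated protein for inhibition of serine/threonine-protein kinase Chk2 (Homo sapiens) (on this read-out higher numbers stand for weaker inhibition and lower numbers for stronger inhibition), compound 3 gives 60 nM, the lowest of the three numbers. Its nearest neighbour is compound 1 at 92 nM; the step of a 1.5-fold lower number from compound 1 to compound 3 (0.19 log units; within the scatter) lies within the scatter, so the two cannot be ordered. Compound 2 differs from compound 3 in several places. Compound 2 gives 4600 nM, a far higher number.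

Compound 4 `OC[C@@H]1CNC[C@H]1Nc1nc(-c2cc(F)ccc2O)nc2ccccc12` is reached from compound 3 by the change (hydroxymethyl in place of hydrogen on a saturated ring carbon). Going by the values given here, no measured step touches the saturated ring of this series in the way this change does. Compound 2, carrying a methyl ester on the same five-membered ring, is the only hint that a substituent there can be tolerated poorly, but its other differences make it no clean guide. Among the compounds with values here, the one clean step, from compound 1 to compound 3, concerns the aromatic ring and does not bear on this change.

Compound 4 is therefore expected to land somewhat higher than compound 3, with the step of a 2.5-fold higher number from compound 3 to compound 4 (0.40 log units; beyond the scatter) carrying wide uncertainty. The estimate for compound 4 in this assay is 150 nM, within 40 nM to 600 nM.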

Compound 4, half-maximal inhibitory concentration: 37 nM
Compound 4: middle estimate off by 4.1-fold (0.61 log units), on the high side; the measured number lies below the stated range.
By their numbers in this assay, from the lowest: compounds 4, 3 and 1 (each within the scatter of the next, the first and the last beyond it); then compound 2.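

In this assay, the step of a 1.6-fold lower number from compound 3 to compound 4 (0.21 log units; within the scatter) shows that this saturated ring carbon, next to the ring atom that bears a large group and two ring bonds from the ring nitrogen, can carry hydroxymethyl without a change in the number that can be read beyond the scatter. Going by these compounds alone, until this step, the only compound with a substituent on this five-membered ring was compound 2, which has a methyl ester there but differs from the others in several places, so no effect of substitution at the ring could be isolated from it. Within the data shown here, the new pair isolates this single change for the first time, and it shows that substitution on this ring carbon does not by itself bring a large rise in the number, although compound 3 and compound 4 cannot be ordered. The compounds shown offer no measured evidence on why the hydroxymethyl group is accommodated here.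

What the compounds leave open is whether the oxygen of hydroxymethyl matters at this carbon, which a comparison with a methyl, an aminomethyl or a methoxymethyl group would address. From the compounds shown here alone, it is also open how far this position extends to a carboxylic acid or a longer chain such as hydroxyethyl.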